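Phenyl in place of methyl: an unchanged dose expected

This account rests on a few compounds, and the source may have more. Where it says the series, first, only, none or still open, it means among the compounds named here.

Compound 1 `O=C(N/N=C(/c1ccccc1)c1ccc(O)cc1)Nc1nnc(COc2ccc3ccccc3c2)o1`: 300 mg/kg
Compound 2 `COc1cc(/C=N\NC(=O)Nc2nnc(COc3ccc4ccccc4c3)o2)ccc1O`: 300 mg/kg
Compound 3 `C/C(=N/NC(=O)Nc1nnc(COc2ccc3ccccc3c2)o1)c1ccc([N+](=O)[O-])cc1`: 300 mg/kg

In a functional assay on the whole organism (strain Wistar) with Rattus norvegicus as the target, with a stated time of 4 h (on this read-out lower numbers stand for an effect already at smaller amounts and higher numbers for an effect only at larger amounts of compound), compound 1 gives 300 mg/kg, compound 2 gives 300 mg/kg and compound 3 gives 300 mg/kg. Compound 3 therefore stands level with compound 1 and compound 2 at the digits shown; the gaps to both lie within the scatter, so no order among the three can be claimed.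

Compound 4 `O=C(N/N=C(/c1ccccc1)c1ccc([N+](=O)[O-])cc1)Nc1nnc(COc2ccc3ccccc3c2)o1` differs from compound 3 by phenyl in place of methyl on a carbon with a double bond to nitrogen. Compound 1 already carries the phenyl at the same kind of carbon and gives 300 mg/kg, no different from compound 3. A step from compound 3 to compound 4 beyond the scatter is not expected in this assay, in either direction; the expected step is no change at the digits printed from compound 3 to compound 4 (within the scatter). Compound 4 is estimated at 300 mg/kg, with a range from 150 mg/kg to 600 mg/kg.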

Compound 4, minimum effective dose: 300 mg/kg
Compound 4: middle estimate and measured number agree at the digits printed; low and high end bracket the measured number.
By their numbers in this assay, from the lowest: compounds 1, 2, 3 and 4 (each within the scatter of the next).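

In this assay, among the compounds shown here, the carbon with a double bond to nitrogen takes phenyl in place of methyl with no change at the digits printed from compound 3 to compound 4 (within the scatter) as the first direct reading of this change, since the earlier compounds held no pair differing in one place. Nitro in place of hydroxy on an aromatic carbon likewise gives no change at the digits printed from compound 1 to compound 4 (within the scatter) as its reading. Nothing measured here offers an explanation for either result.

The compounds shown leave open whether an amine or a carboxylic acid on that aromatic carbon would shift the minimum effective dose. They also leave open whether a longer chain on the carbon with a double bond to nitrogen would do so.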